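Methyl to Fluoro on a Sulfonyl Aryl Ring

This account rests on a few compounds, and the source may have more. Where it says the series, first, only, none or still open, it means among the compounds named here.

Compound 1, `O=C(C1CCC(C(F)(F)F)CC1)N1CC(c2nc(-c3cccc(F)c3)no2)C1`, gives in an assay on HEK293 cells for negative allosteric modulation of metabotropic glutamate receptor 5 (Homo sapiens), read by FLIPR (a lower number here means a stronger inhibitor, a higher number a weaker inhibitor), only a limit, > 10000 nM.
Compound 2, `Cc1cccc(-c2noc(C3CN(C(=O)C4CCC(C(F)(F)F)CC4)C3)n2)c1`, likewise gives only a limit in this assay, > 10000 nM.
Compound 3, `Cc1ccc(S(=O)(=O)N2CC(c3nc(-c4cccc(C)c4)no3)C2)cc1`, gives 670 nM in this assay.

Compound 2 and compound 1 differ by fluoro in place of methyl on an aromatic carbon; the step that the two limits leave unreadable from compound 2 to compound 1 cannot be sized, since both sit at the limit of > 10000 nM in this assay, at which 2 of the 3 values shown sit. Compound 3 carries a sulfonyl-linked aryl instead of the amide of compound 2; that difference between the two cores is not broken down here.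

Compound 4, `Cc1cccc(-c2noc(C3CN(S(=O)(=O)c4ccc(F)cc4)C3)n2)c1`, is not yet measured. It differs from compound 3 by fluoro in place of methyl on an aromatic carbon. This is the same kind of change as from compound 2 to compound 1, but the place differs: there meta to a large group, here para to a large group. With the earlier step unreadable, the expected step is small, a 1.5-fold higher number from compound 3 to compound 4 (0.17 log units; within the scatter), resting only on compound 3 at 670 nM. Compound 4 is therefore estimated at 1000 nM, within 300 nM to 4000 nM.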

Compound 4, half-maximal inhibitory concentration: 950 nM
Estimate against measurement, compound 4: 1.1-fold (0.02 log units) above; the range from low to high includes it.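

In this assay, going from 4-methylphenyl to 4-fluorophenyl gives a 1.4-fold higher number from compound 3 to compound 4 (0.15 log units; within the scatter), so on the core of compound 3 this pair cannot be told apart. This is a single pair, and it does not show that the change would behave the same way on another core. The matching change on the amide-bearing core cannot be read, so the comparison between cores has only one readable side, as compound 2 and compound 1 each give only a limit: the limit of > 10000 nM in this assay, at which 2 of the 4 values shown sit.

On these data alone, it remains open whether a chloro, methoxy or nitrile group in this place would also leave the value within the scatter. As far as these compounds go, it is also open whether an amine or a carboxylic acid there would do so.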